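The source may hold more compounds than are shown below. What is called first, only, known or untested is meant among the compounds shown, and "the series" means these compounds.

Of the compounds shown here, three built on one shared core have been tested in an ADME assay on the whole organism for pharmacokinetics, with Homo sapiens as the target; a higher number here means that a larger share of the oral dose reaches the circulation, a lower number that a smaller share of the oral dose reaches the circulation. Compound 1 `COc1ccccc1NS(=O)(=O)c1ccc2nc(-c3ccccc3)c(-c3ccccc3)nc2c1` gives 100%, compound 2 `CC(=O)c1cccc(NS(=O)(=O)c2ccc3nc(-c4ccccc4)c(-c4ccccc4)nc3c2)c1` gives 96.9%, and compound 3 `O=S(=O)(Nc1ccc(Cl)cc1)c1ccc2nc(-c3ccccc3)c(-c3ccccc3)nc2c1` gives 100% in this assay. Compound 3 matches compound 1 to the digits shown, and its distance to compound 2 is also small: the step of no change at the digits printed from compound 1 to compound 3 (within the scatter) and the step of a number 3.1 percentage points higher from compound 2 to compound 3 (within the scatter) both stay inside the scatter, as does the step of a number 3.1 percentage points lower from compound 1 to compound 2 (within the scatter). All three numbers sit close to the top of what this assay can report.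

Compound 4 `O=S(=O)(Nc1ccccc1)c1ccc2nc(-c3ccccc3)c(-c3ccccc3)nc2c1` differs from compound 3 in one place: hydrogen in place of chloro on an aromatic carbon. Among the measured compounds shown here, no measured pair swaps this particular group, so the closest guidance comes from the three steps already seen, each of which changed the group on the sulfonamide nitrogen without moving the read-out beyond the scatter. On that basis no change beyond the scatter is expected for compound 4, and its value in this assay is estimated at 98%, with a range from 85% to 100%. The expected step of a number 2 percentage points lower from compound 3 to compound 4 (within the scatter) is therefore small, and the measured number will show whether this holds.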

Compound 4, oral bioavailability: 100%
Compound 4: middle estimate off by 2 percentage points, on the low side, and the stated range covers the measured number.
By their numbers in this assay, from the lowest: compounds 2, 1, 3 and 4 (each within the scatter of the next).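

Taking the chloro group off the position para to a large group leaves a plain phenyl on the sulfonamide nitrogen, and in this assay the step is no change at the digits printed from compound 3 to compound 4 (within the scatter). The ring therefore needs no substituent at all to keep this read-out high, which the three substituted compounds alone could not show. The unsubstituted ring also compares closely with the other two, with no change at the digits printed from compound 1 to compound 4 (within the scatter) and a number 3.1 percentage points higher from compound 2 to compound 4 (within the scatter), so across these four compounds neither chloro, methoxy nor acetyl separates from hydrogen, though no information is available on why the read-out stays so flat.

All four numbers lie near the top of the scale, so these compounds show what this ring tolerates only among neutral groups and cannot reveal any gain from a further change. Still open, as far as these compounds go, is whether a carboxylic acid or an amine on this ring, a longer alkyl chain in place of the ring on the sulfonamide nitrogen, or a change to the two phenyl groups on the shared core would bring the number down.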